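The compounds below may be only part of what the source reports. "The series", "measured", "known", "first", "only" and "open" are said of these compounds alone.

Going by the values given here, compound 2, `CC(C)C(Cc1nnc[nH]1)c1ccc(-c2ccc3cccc(F)c3c2)[nH]c1=O`, is one of three compounds measured in a physicochemical assay for solubility, in phosphate buffer, measured as kinetic solubility (on this read-out higher numbers stand for higher solubility and lower numbers for lower solubility), where compound 2 gives 24200 nM. Of the three numbers this is the lowest, yet neither of the others stands clear of it: compound 3, `CC(C)C(c1ccc(-c2ccc3cccc(F)c3c2)[nH]c1=O)N1CCN/C1=N\C#N`, gives 25200 nM, and compound 1, `CCn1ncc2c(F)cc(-c3ccc(C(CC)(CC)c4nnc[nH]4)c(=O)[nH]3)cc21`, gives 35500 nM, both within the usual scatter of repeated measurements around compound 2.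

The next compound, compound 4, is `CC(C)NC(=O)CC(c1ccc(-c2ccc3cccc(F)c3c2)[nH]c1=O)C(C)C`. It differs from compound 2 in one place: isopropylcarbamoyl in place of 4H-1,2,4-triazol-3-yl on a saturated chain carbon, two bonds along the chain from an aromatic carbon.

Among the compounds with values here, only one measured step changes the same position of compound 2. In that step, a 1.0-fold higher number from compound 2 to compound 3 (0.02 log units; within the scatter), the triazole was replaced by a larger ring-bearing group and the number did not move beyond the scatter. The change to compound 4 also removes the triazole, this time for an open-chain amide, and the shared core with its fluorinated ring system is kept. Within the data shown here, there is no measured pair that tests an amide at this position, so the expectation rests on that one step alone: no step beyond the scatter is expected, as a 1.0-fold higher number from compound 2 to compound 4 (0.01 log units; within the scatter).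

The solubility of compound 4 in this assay is therefore estimated at 25000 nM, expected to lie between 10000 nM and 60000 nM.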

Compound 4, solubility: 18000 nM
Compound 4: the middle estimate sits 1.4-fold (0.14 log units) above what was measured; measured number inside the range.
By their numbers in this assay, from the lowest: compounds 4, 2, 3 and 1 (each within the scatter of the next).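

In this assay, replacing the 4H-1,2,4-triazol-3-yl ring with isopropylcarbamoyl, a group with no ring, leaves the number within the scatter (a 1.3-fold lower number from compound 2 to compound 4 (0.13 log units; within the scatter)). The earlier step at this part of the molecule went from one ring-bearing group to another, whereas the comparison of the ring-bearing group in compound 3 with the open-chain group in compound 4 now also stays within the scatter (a 1.4-fold lower number from compound 3 to compound 4 (0.15 log units; within the scatter)), so among compound 2, compound 3 and compound 4 the presence of a ring in this group does not separate the numbers. Nothing measured here explains why these numbers stay so close.

The compounds shown leave open whether a carboxylic acid or a primary amine in place of isopropylcarbamoyl would also stay within the scatter of compound 2, and whether a longer chain leading to the amide would do the same. They also leave open whether swapping the 4H-1,2,4-triazol-3-yl ring of compound 1 for isopropylcarbamoyl, on that different core, would give a similarly small step.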